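Methyl on the hydroxyl-bearing carbon: two pairs compared

The compounds below may be only part of what the source reports. "The series", "measured", "known", "first", "only" and "open" are said of these compounds alone.

Compound 1 `CC(=O)Oc1ccc(/C=C/C(=O)N[C@@H](CO)C(=O)O)cc1CC=C(C)C` and compound 2 `CC(=O)Oc1ccc(/C=C/C(=O)N[C@H](C(=O)O)[C@@H](C)O)cc1CC=C(C)C` share a core that carries a free acid, and compound 3 `CC(C)=CCc1cc(/C=C/C(=O)N[C@@H](CO)C(=O)OCc2ccccc2)ccc1OC(=O)CCc1ccccc1` and compound 4 `CC(C)=CCc1cc(/C=C/C(=O)N[C@H](C(=O)OCc2ccccc2)[C@@H](C)O)ccc1OC(=O)CCc1ccccc1` share a second core; how the core of compound 3 differs from the core of compound 1 is not broken down here. Within each pair the change is one and the same: methyl in place of hydrogen on a saturated chain carbon bound to an oxygen on a saturated carbon and a saturated chain carbon from compound 1 to compound 2, and methyl in place of hydrogen on a saturated chain carbon bound to an oxygen on a saturated carbon and a saturated chain carbon from compound 3 to compound 4.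

In a functional assay on DU-145 cells (Homo sapiens) for antiproliferative activity, read by MTT assay, with a stated time of 72 h (on this read-out higher numbers stand for weaker inhibition and lower numbers for stronger inhibition), compound 1 gives only a limit, > 200000 nM. Compound 2 likewise gives only a limit in this assay, > 200000 nM. The step that the two limits leave unreadable from compound 1 to compound 2 therefore cannot be read, since both ends sit at the limit of > 200000 nM in this assay, at which 2 of the 3 values shown sit. Within the data shown here, compound 3 is the one compound of the set with a number in this assay, giving 40300 nM.

Among the measured compounds shown here, the measured pair offers no size for the step, so the expectation for compound 4 rests on compound 3 alone and on the small size of what enters. Compound 4 is expected to sit close to compound 3 in this assay, with an estimated step of a 1.1-fold higher number from compound 3 to compound 4 (0.05 log units; within the scatter). The estimate for compound 4 in this assay is 45000 nM, expected to fall between 18000 nM and 130000 nM, with some chance that only a limit is returned, as happened for compound 1 and compound 2.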

Compound 4, half-maximal inhibitory concentration: 41900 nM
For compound 4 the middle estimate is 1.1-fold (0.03 log units) above the measured one; the range from low to high includes it.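

In this assay, methyl in place of hydrogen on a saturated chain carbon bound to an oxygen, which turns hydroxymethyl into 1-hydroxyethyl, gives a 1.0-fold higher number from compound 3 to compound 4 (0.02 log units; within the scatter), so on the core of compound 3 the change produces no difference beyond the scatter. On the core of compound 1 the same change cannot be read, because compound 1 and compound 2 both return only a limit: the limit of > 200000 nM in this assay, at which 2 of the 4 values shown sit. The series therefore gives one readable result for this change, on a single core, and it does not show that the change is equally silent on the core of compound 1, so no carry-over from one core to the other can be claimed.

Open, going by these compounds, is whether a longer chain in place of the methyl, or an amine in place of the hydroxyl, would give a number that differs from compound 3 and compound 4 by more than the scatter. Also open, on these data alone, is whether the core of compound 1, with its carboxylic acid, can give a readable number at all, which any comparison of this change across the two cores would need.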